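Oxazole ketones as diacylglycerol lipase-alpha inhibitors: working notes

The source may hold more compounds than are shown below. What is called first, only, known or untested is meant among the compounds shown, and "the series" means these compounds.

Measured compounds, values in an assay on HEK-293T cells for inhibition of diacylglycerol lipase-alpha (Homo sapiens), read by colorimetric assay; a lower number here means a stronger inhibitor, a higher number a weaker inhibitor:
Compound 1, `O=C(CCCCCc1ccccc1)c1nc2ncccc2s1`: > 10000 nM, a limit of the assay and not a number.
Compound 2, `O=C(CCCCCc1ccccc1)c1nc2cc([N+](=O)[O-])ccc2o1`: 891 nM.
Compound 3, `CC(C)(C)C(=O)c1coc(C(=O)CCCCCCc2ccccc2)n1`: 479 nM.

Compound 3 gives the lowest of the two numbers in this assay; the nearest is compound 2, and the gap between compound 3 and compound 2 lies within the usual scatter, so no order between them is claimed. For compound 1 only the limit is known (the limit of > 10000 nM in this assay, at which 1 of the 3 values shown sits).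

Compound 4, `Cc1coc(C(=O)CCCCCCc2ccccc2)n1`, is not yet measured. It differs from compound 3 in one place: methyl in place of (tert-butyl)carbonyl on an aromatic carbon of the five-membered ring with one nitrogen and one oxygen. Going by the values given here, no measured pair shows this kind of change, so the expectation rests on compound 3 alone. The loss of the carbonyl-bearing group is expected to weaken inhibition moderately, beyond the scatter but not to the limit; the expected step is a 3.1-fold higher number from compound 3 to compound 4 (0.50 log units; beyond the scatter). Compound 4 is estimated at 1500 nM in this assay, with a range from 400 nM to 6000 nM.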

Compound 4, half-maximal inhibitory concentration: > 10000 nM
Compound 4 was reported as a limit; the forecaster's own chance of this, stated with the estimate: 15%; middle value at least 6.6-fold (0.82 log units) away from the limit.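

In this assay, the group on the aromatic carbon next to the ring nitrogen proves decisive for this series: methyl in place of (tert-butyl)carbonyl gives an at least 20-fold higher number from compound 3 to compound 4 (1.31 log units; beyond the scatter). Going by these compounds alone, this is the first single-place change available here, and it shows that the chain and the rest of the core shared by these two compounds do not by themselves sustain the inhibition seen for compound 3. Compound 4 gives > 10000 nM, a limit of the assay and not a number, so the step marks only a minimum size: the limit of > 10000 nM in this assay, at which 2 of the 4 values shown sit.

The compounds shown do not separate the contribution of the carbonyl from that of the tert-butyl group. An acetyl group, an amide or a carboxylic acid on this carbon would test which part matters.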